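The compounds below may be only part of what the source reports. "The series", "measured", "known", "first", "only" and "open" are said of these compounds alone.

Of the compounds shown here, three have been measured so far in this study. Compound 1 `N=C(N)NCCC[C@H](NC(=O)CN(c1nc(Cl)nc2[nH]cnc12)C1CC1)C(=O)O`, compound 2 `O=C(CN(c1nc(Cl)nc2[nH]cnc12)C1CC1)N[C@@H](CC(=O)OCc1ccccc1)C(=O)OCc1ccccc1` and compound 3 `C[C@@H](O)[C@H](NC(=O)CN(c1ncnc2c1ncn2C1CCCCO1)C1CC1)C(=O)OCc1ccccc1` were all tested in a functional assay on the whole organism (Tail, strain ICR) with Mus musculus as the target, in the tail flick test, with a stated time of 150 min, at a dose of 25 umol/kg by the oral route; on this read-out higher numbers stand for a stronger effect at the one dose given and lower numbers for a weaker effect. In this assay compound 1 gives 7.19%, compound 2 gives 6.68% and compound 3 gives 6.53%. The number for compound 3 is the lowest of the three, yet both of the other numbers lie within the usual scatter of it, so the three compounds cannot be told apart on these data and none may be called weaker or stronger than another.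

Compound 4 `C[C@H](NC(=O)CN(c1ncnc2c1ncn2C1CCCCO1)C1CC1)C(=O)OCc1ccccc1` is the next compound to be measured in this assay. It differs from compound 3 in one place: methyl in place of 1-hydroxyethyl on a saturated chain carbon bound to an amide-type nitrogen and a carbonyl carbon. Going by the values given here, no pair of measured compounds differs in a single place, so no measured step can guide the expectation. Since compound 1, compound 2 and compound 3 all sit close together at low activity in this assay, the step expected from compound 3 to compound 4 is a number 0 percentage points lower from compound 3 to compound 4 (within the scatter), that is, none beyond the scatter. Compound 4 is therefore estimated to give 6.5% in this assay, with a range from 1.5% to 12%.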

Compound 4, a percentage reported as activity, at one dose (the size of the read-out at that dose, not a potency): 6.01%
Beside the measured number, compound 4's estimate is 0.5 percentage points above it, and the stated range covers the measured number.
By their numbers in this assay, from the lowest: compounds 4, 3, 2 and 1 (each within the scatter of the next).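

Going by these compounds alone, the swap of 1-hydroxyethyl for methyl gives the first single-place comparison in this assay: on a saturated chain carbon bound to an amide-type nitrogen and a carbonyl carbon, it produces a number 0.5 percentage points lower from compound 3 to compound 4 (within the scatter). The change removes one hydrogen-bond donor, one hydrogen-bond acceptor and a defined stereocentre, yet the read-out cannot be told apart from that of the parent compound. At this place, then, the hydroxyl-bearing side chain is not needed to keep the read-out at its present low level. No available measurement explains this result.

From the compounds shown here alone, whether an isopropyl group or a primary amine on this carbon would move the read-out stays open. So does whether the same swap would make a difference in a compound with a stronger effect.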